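The source may report more compounds than this note shows. Statements on the series, on what has been measured and on what is new or still open speak of the compounds shown alone.

In an ADME assay on RAW264.7 cells (Mus musculus) for cytotoxicity, read by MTT assay, with a stated time of 24 h, in the absence of a further agent (on this read-out higher numbers stand for weaker inhibition and lower numbers for stronger inhibition), three compounds have been measured so far, and none gave a true number. Compound 1 (`O=C1OC(Cc2nc(-c3ccc(Oc4ccccc4)cc3)no2)c2ccccc21`) reads > 40000 nM, which is a limit of the assay. Compound 2 (`COc1cc(OC)c2c(c1)C(C(O)c1ccc(O)cc1)OC2=O`) reads > 40000 nM, also a limit. Compound 3 (`COCCCOc1ccc(C(O)C2OC(=O)c3c(OC)cc(OC)cc32)cc1`) reads > 40000 nM, again a limit. Compound 3 thus shares (the limit of > 40000 nM in this assay, at which 3 of the 3 values shown sit).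

The next compound, compound 4 (`COc1cc(OC)c2c(c1)C(C(O)c1ccc(OCc3ccc(Br)cc3)cc1)OC2=O`), keeps the core of compound 3 and changes the end of the chain on the oxygen: 4-bromophenyl in place of 2-methoxyethyl on a saturated chain carbon bound to an oxygen on an aromatic ring. Put simply, 4-bromophenyl comes in place of 2-methoxyethyl, so that 3-methoxypropyl becomes 4-bromobenzyl.

Going by the values given here, the expectation rests on a step that the two limits leave unreadable from compound 2 to compound 3, the one measured step at this oxygen. It shows no movement, though a real change could remain hidden behind the limits. The expected step, a number no higher from compound 3 to compound 4 (the limit leaves the size open), is therefore none beyond the scatter in either direction. Compound 4 is estimated at 40000 nM, with an expected range from 15000 nM to 80000 nM, and it is expected to read most likely as a limit again.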

Compound 4, half-maximal inhibitory concentration: > 40000 nM
Compound 4 was reported as a limit; the forecaster's own chance of this, stated with the estimate: 75%; the middle value sits exactly at the limit.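

Compound 4 is again a limit, so neither its step from compound 3 nor its step from compound 2 can be read. The compounds shown leave open how far any change on this oxygen moves the value in this assay, since all share one reading: the limit of > 40000 nM in this assay, at which 4 of the 4 values shown sit.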